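Shortening the amine tail on a combretastatin-like stilbene ether

The compounds below may be only part of what the source reports. "The series", "measured", "known", "first", "only" and "open" are said of these compounds alone.

The three measured compounds share one core, seen in compound 1 `COc1ccc(/C=C\c2cc(OC)c(OC)c(OC)c2)cc1OCc1ccc(CN2CCCC[C@H]2C(=O)O)cc1`, compound 2 `COc1ccc(/C=C\c2cc(OC)c(OC)c(OC)c2)cc1OCc1ccc(CN2CC[C@H](O)C2)cc1` and compound 3 `COc1ccc(/C=C\c2cc(OC)c(OC)c(OC)c2)cc1OCc1ccc(CN2CCCCC2C(=O)NCCN)cc1`, and differ only in the amine group set on a saturated chain carbon bound to an aromatic carbon. In a functional assay on HepG2 cells (Homo sapiens) for antiproliferative activity, read by CCK-8 assay, with a stated time of 48 h (a higher number here means a weaker inhibitor, a lower number a stronger inhibitor), compound 1 reaches only the limit of > 10000 nM. In this assay compound 2 gives 6600 nM and compound 3 gives 4800 nM, so compound 3 has the lowest number of the two values, though that gap is a 1.4-fold lower number from compound 2 to compound 3 (0.14 log units; within the scatter), within the scatter. The step of an at least 2.0-fold lower number from compound 1 to compound 3 (0.31 log units; beyond the scatter) is at least modest, and an at least 1.5-fold lower number from compound 1 to compound 2 (0.18 log units; that floor lies within the scatter) rests on a limit (the limit of > 10000 nM in this assay, at which 1 of the 3 values shown sits).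

Compound 4 `COc1ccc(/C=C\c2cc(OC)c(OC)c(OC)c2)cc1OCc1ccc(CNCCN(C)C)cc1` is not yet measured. Its change is (2-(dimethylamino)ethyl)amino in place of 2-((2-aminoethyl)carbamoyl)piperidin-1-yl on a saturated chain carbon bound to an aromatic carbon. Going by the values given here, the steps that bear on it are those arriving at compound 3, all small, so no step beyond the scatter is expected. For compound 4 an estimated value of 4500 nM in this assay, between 1500 nM and 13000 nM, is expected, meaning a step of a 1.1-fold lower number from compound 3 to compound 4 (0.03 log units; within the scatter).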

Compound 4, half-maximal inhibitory concentration: 4400 nM
For compound 4 the middle estimate is 1.0-fold (0.01 log units) above the measured one; measured number inside the range.
By their numbers in this assay, from the lowest: compounds 4, 3 and 2 (each within the scatter of the next). At a limit, above all of these: compound 1.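

At this place, on a saturated chain carbon bound to an aromatic carbon, the shared core tolerates the loss of both the ring and the carbonyl of 2-((2-aminoethyl)carbamoyl)piperidin-1-yl: in this assay, the open-chain (2-(dimethylamino)ethyl)amino gives a 1.1-fold lower number from compound 3 to compound 4 (0.04 log units; within the scatter). The swap for 3-hydroxypyrrolidin-1-yl also stays within the scatter, at a 1.5-fold lower number from compound 2 to compound 4 (0.18 log units; within the scatter), so a group with no ring is not distinguished here from the two ring amines. The step of an at least 2.2-fold lower number from compound 1 to compound 4 (0.35 log units; beyond the scatter) is at least modest, but it rests on a limit rather than a number: the limit of > 10000 nM in this assay, at which 1 of the 4 values shown sits.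

The compounds shown leave open whether a piperazine, a morpholine or a (3-(dimethylamino)propyl)amino chain in this place would move the number beyond the scatter. From the compounds shown here alone, the true size of the gap to compound 1 also stays open, as its value is a limit.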